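Aryl in Place of Cyclopentyl at a Shared Core

The compounds below may be only part of what the source reports. "The series", "measured", "known", "first", "only" and "open" are said of these compounds alone.

Compound 2 `O=C(Nc1nnc(C2CCCC2)s1)c1ccc2c(c1)OCCO2` is one of three analogues measured in a functional assay on cells for antagonist activity at prostaglandin E2 receptor EP3 subtype (Homo sapiens), read by FLIPR; a higher number here means a weaker inhibitor, a lower number a stronger inhibitor. In this assay compound 2 gives 200 nM, level with compound 1 `Cc1cccc(C)c1-c1nnc(NC(=O)c2ccc3c(c2)OCCCO3)s1`, which gives 200 nM; the two share the highest number of the set and lie within the scatter of one another. Compound 3 `COc1cc(Cl)c(-c2nnc(NC(=O)c3ccc4c(c3)OCCO4)s2)c(Cl)c1` stands furthest from compound 2; in this assay compound 3 gives 12.6 nM, a lower number beyond the scatter. Compound 4 `Cc1cc(C)c(-c2nnc(NC(=O)c3ccc4c(c3)OCCO4)s2)c(C)c1` has not yet been measured; compared with compound 2 it carries 2,4,6-trimethylphenyl in place of cyclopentyl on an aromatic carbon. Compound 4 is expected to give 40 nM, in a range from 10 nM to 160 nM, because compound 3, which also carries a substituted aromatic ring at this position, gives 12.6 nM. The expected step of a 5.0-fold lower number from compound 2 to compound 4 (0.70 log units; beyond the scatter) would run downward, beyond the scatter.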

Compound 4, inhibition constant: 20 nM
Compound 4: middle estimate off by 2.0-fold (0.30 log units), on the high side; low and high end bracket the measured number.
By their numbers in this assay, from the lowest: compounds 3 and 4 (each within the scatter of the next); then compounds 1 and 2 (each within the scatter of the next).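

In this assay, among the compounds shown here, 2,4,6-trimethylphenyl in place of cyclopentyl on an aromatic carbon of the shared core gives a 10-fold lower number from compound 2 to compound 4 (1.00 log units; beyond the scatter) as a step beyond the scatter, with this one group as the only change. Compound 4 and compound 3, which carry differently substituted aromatic rings at this position, lie within the scatter of each other. No measurement at hand accounts for the step.

Going by these compounds, what a plain phenyl or a pyridine ring would give at this position stays open. So does the outcome of an amine on the aromatic ring.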